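Lengthening the Chain by One Carbon on Compound 3

The compounds below may be only part of what the source reports. "The series", "measured", "known", "first", "only" and "open" are said of these compounds alone.

Compound 3 `CCCOCNc1n[n+]([O-])c2ccccc2[n+]1[O-]` gives 7400 nM in a functional assay on PC-3 cells (Homo sapiens) for cytotoxicity, read by MTT assay, with a stated time of 72 h (a lower number here means a stronger inhibitor, a higher number a weaker inhibitor), the highest of the three numbers shown, yet compound 1 `[O-][n+]1nc(NCOC2CCCCC2)[n+]([O-])c2ccccc21` at 6670 nM and compound 2 `[O-][n+]1nc(NCOCc2ccc(Cl)cc2)[n+]([O-])c2ccccc21` at 5100 nM both lie within the scatter of it. Compound 4 `CCCCOCNc1n[n+]([O-])c2ccccc2[n+]1[O-]` differs from compound 3 by methyl in place of hydrogen on a saturated chain carbon, three bonds along the chain from an oxygen on a saturated carbon. For the measured compounds named here, two measured steps touch the same end of the chain: a 1.1-fold higher number from compound 1 to compound 3 (0.05 log units; within the scatter) and a 1.5-fold higher number from compound 2 to compound 3 (0.16 log units; within the scatter), each within the scatter, so swapping what sits there has so far shifted nothing that can be trusted. In this assay the expected step is therefore a 1.1-fold lower number from compound 3 to compound 4 (0.02 log units; within the scatter), nothing beyond the scatter. Compound 4 is estimated at 7000 nM, in a range from 3500 nM to 14000 nM.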

Compound 4, half-maximal inhibitory concentration: 6010 nM
Estimate against measurement, compound 4: 1.2-fold (0.07 log units) above; the range from low to high includes it.
By their numbers in this assay, from the lowest: compounds 2, 4, 1 and 3 (each within the scatter of the next).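

Going from propyl to butyl gives a 1.2-fold lower number from compound 3 to compound 4 (0.09 log units; within the scatter) in this assay and so adds a carbon to the chain without a change that can be trusted. Replacing a ring-bearing group with a plain chain does no more: propyl in place of 4-chlorophenyl gives a 1.2-fold higher number from compound 2 to compound 4 (0.07 log units; within the scatter) and butyl in place of cyclohexyl gives a 1.1-fold lower number from compound 1 to compound 4 (0.05 log units; within the scatter) and both stay within the scatter. No outside evidence accounts for these small steps.

From the compounds shown here alone, whether an octyl chain would move the number remains open. So does whether an amine or a carboxylic acid in place of butyl would do so.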